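Replacing 4-bromophenyl with 3-cyanophenyl on an amide-type nitrogen

The source may hold more compounds than are shown below. What is called first, only, known or untested is meant among the compounds shown, and "the series" means these compounds.

In a functional assay on A549 cells (Homo sapiens) for inhibition, read by CCK-8 assay, with a stated time of 72 h, tested at 10 uM (on this read-out lower numbers stand for less inhibition of growth and higher numbers for more inhibition of growth at the one concentration tested), compound 1 (`CN(C)C(=O)c1cc2cnc(Nc3ccc(NC(=O)C4(C(=O)Nc5ccc(Cl)cc5)CC4)cc3)nc2n1C1CCCC1`) gives 101% and compound 2 (`CN(C)C(=O)c1cc2cnc(Nc3ccc(NC(=O)C4(C(=O)Nc5cccc(F)c5)CC4)cc3)nc2n1C1CCCC1`) gives 91.8% while compound 3 (`CN(C)C(=O)c1cc2cnc(Nc3ccc(NC(=O)C4(C(=O)Nc5ccc(Br)cc5)CC4)cc3)nc2n1C1CCCC1`) gives 90.3% on the same read-out. Two steps place this last compound among the three numbers: a number 1.5 percentage points lower from compound 2 to compound 3 (within the scatter) and a number 10.7 percentage points lower from compound 1 to compound 3 (beyond the scatter) in this small series. Compound 4 (`CN(C)C(=O)c1cc2cnc(Nc3ccc(NC(=O)C4(C(=O)Nc5cccc(C#N)c5)CC4)cc3)nc2n1C1CCCC1`) has 3-cyanophenyl in place of 4-bromophenyl on an amide-type nitrogen. Within the data shown here, no measured step makes this exact change. The nearest exchanges on that nitrogen are a number 9.2 percentage points lower from compound 1 to compound 2 (within the scatter) and the first of the two steps above, and neither goes beyond the scatter. The expected step is therefore a number 0.3 percentage points lower from compound 3 to compound 4 (within the scatter) with no direction expected beyond the scatter. For compound 4 the estimated value is 90% with an expected range from 78% to 101% on this read-out.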

Compound 4, percent growth inhibition at one concentration: 73.6%
Compound 4: middle estimate off by 16.4 percentage points, on the high side, and the stated range ends above it.
By their numbers in this assay, from the lowest: compound 4; then compounds 3, 2 and 1 (each within the scatter of the next, the first and the last beyond it).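

In this assay, 3-cyanophenyl on the amide-type nitrogen gives a lower number than each of the three halogen-bearing phenyl groups: a number 16.7 percentage points lower from compound 3 to compound 4 (beyond the scatter), a number 18.2 percentage points lower from compound 2 to compound 4 (beyond the scatter) and a number 27.4 percentage points lower from compound 1 to compound 4 (beyond the scatter). Cyano in place of fluoro alone gives a step beyond the scatter, so this position responds to the group it carries. Nothing available explains this lower number. The compounds shown leave open whether the loss belongs to the nitrile itself or to where it sits on the ring, and how an aminophenyl or carboxyphenyl group on that nitrogen would read.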